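Ester chain variation in a pyridinyl-benzamide ROCK2 series

This account rests on a few compounds, and the source may have more. Where it says the series, first, only, none or still open, it means among the compounds named here.

Measured so far:
compound 1, `COC(=O)c1cccc(-c2cc(C(=O)Nc3ccncc3)ccc2CN)c1`: 2.9 nM
compound 2, `CCCOC(=O)c1cccc(-c2cc(C(=O)Nc3ccncc3F)ccc2CN)c1`: 5.1 nM

Of the compounds shown here, two of the shared core have been tested in an assay on isolated protein for inhibition of Rho-associated protein kinase 2 (Homo sapiens), read by radiometric assay; a higher number here means a weaker inhibitor, a lower number a stronger inhibitor. Compound 1 gives 2.9 nM, and compound 2 gives 5.1 nM. Compound 2 sits at one end of this pair of numbers, but the gap to compound 1 is within the usual scatter, so the two are not separated by the data. Within the data shown here, both carry a pyridine-amide and an aminomethyl group on the core; they differ in the ester and in the fluorine on the pyridine, and no single-point step between them is defined.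

The next compound, compound 3, `NCc1ccc(C(=O)Nc2ccncc2F)cc1-c1cccc(C(=O)OCC2CCCO2)c1`, keeps the fluoropyridine of compound 2 and changes only the ester end: oxolan-2-yl in place of ethyl on a saturated chain carbon bound to an oxygen next to a carbonyl group. The saturated chain on this ester already varies between compound 1 and compound 2 without a separation beyond the scatter, which suggests the ester end tolerates change.

Compound 3 is therefore expected to stay close to compound 2, with a step of a 1.2-fold higher number from compound 2 to compound 3 (0.07 log units; within the scatter) no larger than the scatter, giving an estimated 6 nM in this assay, within 2.5 nM to 15 nM.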

Compound 3, half-maximal inhibitory concentration: 2.5 nM
Compound 3: middle estimate off by 2.4-fold (0.38 log units), on the high side; measured number inside the range.
By their numbers in this assay, from the lowest: compounds 3, 1 and 2 (each within the scatter of the next, the first and the last beyond it).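

Oxolan-2-yl in place of ethyl on a saturated chain carbon bound to an oxygen next to a carbonyl group gives a 2.0-fold lower number from compound 2 to compound 3 (0.31 log units; beyond the scatter) in this assay, the first step in the series that can be read at a single place. The earlier pair left the ester end unresolved, whereas this step shows that the position accepts a five-membered non-aromatic ring with one hetero atom and one hydrogen-bond acceptor, and that the number moves modestly lower with this change. No measurement at hand bears on the origin of this step.

Among these compounds, with only this one step at the position, the ring oxygen and the larger group remain unseparated, and a cyclopentylmethyl ester or a pentyl ester would bear on that question. Also open, on these data alone, are whether the same change holds on the core of compound 1 and what a carboxylic acid or an amide in place of the ester would give.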